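The compounds below may be only part of what the source reports. "The series", "measured", "known", "first", "only" and "open" are said of these compounds alone.

Measured compounds:
compound 1, `Cc1ccnc(OCc2ccc(F)cc2)c1C(=O)NC1CCCCCC1`: > 10000 nM
compound 2, `O=C(NC1CCCCCC1)c1c(-c2ccccc2)c(Br)cn(Cc2ccc(F)cc2)c1=O`: 3000 nM
compound 3, `O=C(NC1CCCCCC1)c1c(-c2ccccc2)ccn(Cc2ccc(F)cc2)c1=O`: > 10000 nM

In an assay on HEK293 cells for inhibition of Monoacylglycerol lipase ABHD6 (Homo sapiens), with stated times of 30 min and 5 min (a higher number here means a weaker inhibitor, a lower number a stronger inhibitor), compound 2 gives 3000 nM. Compound 3 gives only a limit there, > 10000 nM. Compound 1 also gives only a limit, > 10000 nM. The change between compound 3 and compound 2 is bromo in place of hydrogen on an aromatic carbon, and it produced an at least 3.3-fold lower number from compound 3 to compound 2 (0.52 log units; beyond the scatter). Compound 4, `Cc1c(Br)cnc(OCc2ccc(F)cc2)c1C(=O)NC1CCCCCC1`, carries the same kind of change on the core of compound 1: bromo in place of hydrogen on an aromatic carbon. The difference between the two cores is not broken down here. The surroundings differ: in compound 4 the bromo sits ortho to a methyl group, meta to a large group and para to a (4-fluorobenzyl)oxy group, whereas in compound 2 it sits ortho to a phenyl group, meta to a 4-fluorobenzyl group, meta to a cycloheptylcarbamoyl group and para to a group of 1 heavy atom. Compound 1 is expected to shift by an at least 1.2-fold lower number from compound 1 to compound 4 (0.09 log units; that floor lies within the scatter) in this assay, an expectation resting on an at least 3.3-fold lower number from compound 3 to compound 2 (0.52 log units; beyond the scatter). Because of the limit of > 10000 nM in this assay, at which 2 of the 3 values shown sit, a limit rather than a number remains possible for compound 4. Compound 4 is expected at 8000 nM in this assay, between 2500 nM and 30000 nM.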

Compound 4, half-maximal inhibitory concentration: 530 nM
Beside the measured number, compound 4's estimate is 15-fold (1.18 log units) above it; measured number below the stated range.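

In this assay, bromo in place of hydrogen on an aromatic carbon gives an at least 18-fold lower number from compound 1 to compound 4 (1.27 log units; beyond the scatter) on this second core. The direction of the change therefore holds on both cores shown, and on each the step lies beyond the scatter, though two pairs establish no general rule for the series. Whether the size of the step carries over from one core to the other is not shown: the same change on two cores in this assay, an at least 3.3-fold lower number (0.52 log units; beyond the scatter) from compound 3 to compound 2 and an at least 18-fold lower number (1.27 log units; beyond the scatter) from compound 1 to compound 4; the limit leaves it open whether they differ.

Bromo is the only group shown at this ring carbon, so it remains open whether chloro or a nitrile there would go with a similar step. Also open, on these data alone, is whether the step persists when an amine or a carboxylic acid replaces the cycloheptylcarbamoyl group.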